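Swapping imidazole for pyrrole on the propyl chain

The compounds below may be only part of what the source reports. "The series", "measured", "known", "first", "only" and "open" are said of these compounds alone.

- compound 1 `Cn1cc(C2=C(c3nn(CCn4ccnc4)c4ncccc34)C(=O)N(c3ccccc3)C2=O)c2ccccc21`: 43100 nM
- compound 2 `Cn1cc(C2=C(c3nn(CCCn4cccc4)c4ncccc34)C(=O)NC2=O)c2ccccc21`: > 100000 nM (a limit of the assay, not a number)
- compound 3 `Cn1cc(C2=C(c3nn(CCCn4ccnc4)c4ncccc34)C(=O)N(c3ccccc3)C2=O)c2ccccc21`: 1560 nM

These values come from a functional assay on A549 cells (Homo sapiens) for antiproliferative activity, read by MTT assay, with a stated time of 48 h; a higher number here means a weaker inhibitor, a lower number a stronger inhibitor. Compound 3, at 1560 nM, has the lower of the two true numbers, and compound 1 gives 43100 nM.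

Compound 4 `Cn1cc(C2=C(c3nn(CCCn4cccc4)c4ncccc34)C(=O)N(c3ccccc3)C2=O)c2ccccc21` is the next structure to be tested. It differs from compound 3 in one place, with 1H-pyrrol-1-yl in place of 1H-imidazol-1-yl on a saturated chain carbon, three bonds along the chain from an aromatic nitrogen.

Within the data shown here, the only measured step in this set, a 28-fold lower number from compound 1 to compound 3 (1.44 log units; beyond the scatter), is large. It extends the chain and keeps the 1H-imidazol-1-yl group, so it shows that this part of the molecule can matter but says nothing direct about swapping the ring.

Compound 2 also carries the 1H-pyrrol-1-yl group. Compound 2 reads > 100000 nM, which is only a limit. It hints at weakness without isolating this swap, so only a moderate move toward a higher number is expected, with wide uncertainty.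

The expected step is a 2.6-fold higher number from compound 3 to compound 4 (0.41 log units; beyond the scatter). The estimate for compound 4 is 4000 nM, with an expected range of 800 nM to 30000 nM.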

Compound 4, half-maximal inhibitory concentration: > 100000 nM
Compound 4: only a limit was reported; the forecaster's own chance of this, stated with the estimate: 10%; middle value at least 25-fold (1.39 log units) away from the limit.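

In this assay, among these compounds, the ring at the end of the propyl chain turns out to matter a great deal: an at least 64-fold higher number from compound 3 to compound 4 (1.80 log units; beyond the scatter), and the only change is that 1H-imidazol-1-yl, with two ring nitrogens and two hydrogen-bond acceptors, gives way to 1H-pyrrol-1-yl, with one of each. Compound 4 gives > 100000 nM, which is a limit of the assay and not a number, so this step sets only a minimum size, and the same ceiling applies elsewhere in this small set: the limit of > 100000 nM in this assay, at which 2 of the 4 values shown sit. The longer chain alone therefore does not carry the gain seen earlier, since an at least 2.3-fold higher number from compound 1 to compound 4 (0.36 log units; beyond the scatter), leaving the pyrrole compound on the longer chain behind the imidazole compound on the shorter one.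

As far as these compounds go, the step between compound 2 and compound 4 cannot be read, since both values are limits, so the effect of the phenyl on the amide-type nitrogen with the pyrrole in place remains unknown. From the compounds shown here alone, it also remains open how a triazole ring or an open-chain amine at the end of the propyl chain would read, or a longer chain carrying 1H-imidazol-1-yl.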